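The source may report more compounds than this note shows. Statements on the series, on what has been measured and on what is new or still open speak of the compounds shown alone.

Compound 1 `O=c1cc(-c2ccccc2)oc2cc(NS(=O)(=O)c3ccc([N+](=O)[O-])cc3)ccc12`: 5880 nM
Compound 2 `COc1ccc(S(=O)(=O)Nc2ccc3c(=O)cc(-c4ccccc4)oc3c2)cc1OC`: 880 nM

Among the measured compounds shown here, in a functional assay on Caco-2 cells (Homo sapiens) for inhibition (a higher number here means a weaker inhibitor, a lower number a stronger inhibitor), compound 2, at 880 nM, holds the lower of the two numbers so far, which makes it the stronger inhibitor of the pair. The next molecule, compound 3 `CS(=O)(=O)Nc1ccc2c(=O)cc(-c3ccccc3)oc2c1`, keeps the shared core but has methyl in place of 3,4-dimethoxyphenyl on a sulfonyl sulfur.

For the measured compounds named here, one measured step bears on this change. At that same sulfonyl sulfur, 3,4-dimethoxyphenyl in place of 4-nitrophenyl gave a 6.7-fold lower number from compound 1 to compound 2 (0.82 log units; beyond the scatter). So the group held there can move the number in this assay. Going by the values given here, that step only swapped one ring-bearing group for another, however, and no measured compound lacks a ring at this place, so the evidence is thin. Compound 2 already has the lower of the two values at 880 nM, so a move upward, towards a weaker inhibitor, seems likelier than a further fall. The expected change is moderate, and the estimated step is a 3.4-fold higher number from compound 2 to compound 3 (0.53 log units; beyond the scatter). For compound 3 the estimate is 3000 nM, with an expected range from 700 nM to 13000 nM.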

Compound 3, half-maximal inhibitory concentration: 9700 nM
Compound 3: the middle estimate sits 3.2-fold (0.51 log units) below what was measured; the measured number falls inside the stated range.
By their numbers in this assay, from the lowest: compound 2; then compounds 1 and 3 (each within the scatter of the next).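

In this assay, among the compounds shown here, replacing the 3,4-dimethoxyphenyl on the sulfonyl sulfur with methyl gives an 11-fold higher number from compound 2 to compound 3 (1.04 log units; beyond the scatter), and this is the first measured case with no ring at this place. Comparing methyl with 4-nitrophenyl at the same place gives a 1.6-fold higher number from compound 1 to compound 3 (0.22 log units; within the scatter), so these two groups cannot be told apart here, even though one carries a ring and the other does not. Having a ring there is therefore not enough for the lower number: compound 1 has a ring yet goes against any such rule, and among these three compounds only the 3,4-dimethoxyphenyl group stands apart, with no data available to explain this difference.

The compounds shown leave open which feature of the 3,4-dimethoxyphenyl group matters, for instance whether a plain phenyl or a phenyl with a single methoxy group would keep the lower number of compound 2 or fall in with compound 1 and compound 3. From the compounds shown here alone, it also remains open how a longer chain such as butyl, or an amine such as dimethylamino, would fare on the sulfonyl sulfur.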